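Compound 3: nitro in place of bromo

The compounds below may be only part of what the source reports. "The series", "measured", "known", "first", "only" and "open" are said of these compounds alone.

Measured so far in a functional assay on Caco-2 cells (Homo sapiens) for antiproliferative activity, read by MTT assay; a higher number here means a weaker inhibitor, a lower number a stronger inhibitor
- compound 1 `NS(=O)(=O)c1ccc(/N=C2\NC(=O)/C(=C3/C(=O)Nc4ccc(Cl)cc43)S2)cc1` gives 20300 nM
- compound 2 `NS(=O)(=O)c1ccc(/N=C2\NC(=O)/C(=C3/C(=O)Nc4ccc(Br)cc43)S2)cc1` gives 42300 nM

Compound 2, at 42300 nM in this assay pair, holds the higher of the two numbers. Compound 3 `NS(=O)(=O)c1ccc(/N=C2\NC(=O)/C(=C3/C(=O)Nc4ccc([N+](=O)[O-])cc43)S2)cc1` has nitro in place of bromo on an aromatic carbon on the same core. Going by the values given here, the only measured step that bears on this is a 2.1-fold higher number from compound 1 to compound 2 (0.32 log units; beyond the scatter) for bromo in place of chloro, a modest change that does not test nitro. A similarly modest step in this assay is therefore expected, leaning towards a lower number, though the direction is uncertain. The estimate means a 1.7-fold lower number from compound 2 to compound 3 (0.23 log units; within the scatter) as the expected step. Compound 3 is estimated at 25000 nM with a range of 8000 nM to 70000 nM expected.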

Compound 3, half-maximal inhibitory concentration: 13800 nM
For compound 3 the middle estimate is 1.8-fold (0.26 log units) above the measured one; the range from low to high includes it.
By their numbers in this assay, from the lowest: compounds 3 and 1 (each within the scatter of the next); then compound 2.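

In this assay this aromatic carbon accepts nitro, with three heavy atoms and two hydrogen-bond acceptors, in place of a single halogen: a 3.1-fold lower number from compound 2 to compound 3 (0.49 log units; beyond the scatter) is a modest gain, while a 1.5-fold lower number from compound 1 to compound 3 (0.17 log units; within the scatter) does not separate nitro from chloro. Among these three groups, only bromo stands apart, with the highest number. Nothing available explains why bromo differs from the other two groups. As far as these compounds go, whether an amine or a carboxylic acid on this carbon would stay level with compound 1 and compound 3 remains open.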